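A few compounds are considered here, and "the series" means these few. Any claim that something is new, unique, unknown or untested is made for them only; others in the source may bear on it.

Compound 1 `C(#Cc1nc2c(s1)CN(C1CCCCC1)CC2)c1ccccc1` gives > 10000 nM in an assay on HEK293 cells for negative allosteric modulation of metabotropic glutamate receptor 5 (Homo sapiens), read by FLIPR, with a stated time of 1 h (a lower number here means a stronger inhibitor, a higher number a weaker inhibitor), which is a limit of the assay and not a number.
Compound 2 `O=C(C1CC1)N1CCc2nc(C#Cc3ccccc3)sc2C1` gives 290 nM in this assay.
Compound 3 `CC1CCC(C(=O)N2CCc3nc(C#Cc4ccccc4)sc3C2)CC1` gives > 10000 nM in this assay, again a limit and not a number.

Compound 3 therefore stands at the assay limit, the position at which two of the three values sit (the limit of > 10000 nM in this assay, at which 2 of the 3 values shown sit). Compound 4 `Cc1nc(C(=O)N2CCc3nc(C#Cc4ccccc4)sc3C2)cs1` differs from it in one place: 2-methyl-1,3-thiazol-4-yl in place of 4-methylcyclohexyl on a carbonyl carbon.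

Among the compounds with values here, two measured steps bear on the carbonyl substituent. The step of an at least 34-fold lower number from compound 1 to compound 2 (1.53 log units; beyond the scatter) shows a large gain when a cyclopropylcarbonyl is introduced on the ring nitrogen in place of cyclohexyl. The step of an at least 34-fold higher number from compound 2 to compound 3 (1.53 log units; beyond the scatter) shows a loss of the same size when the cyclopropyl on that carbonyl is replaced by 4-methylcyclohexyl. Compound 4 removes the 4-methylcyclohexyl again and brings in a smaller aromatic group, so a large step back toward compound 2 is expected, an at least 16-fold lower number from compound 3 to compound 4 (1.22 log units; beyond the scatter), though a number rather than a limit is not certain. The estimate for compound 4 is 600 nM, with a range from 120 nM to 5000 nM.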

Compound 4, half-maximal inhibitory concentration: > 10000 nM
Compound 4: a limit, no number; the forecaster's own chance of this, stated with the estimate: 25%; at least 16-fold (1.22 log units) between middle value and limit.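

Replacing cyclopropyl on the carbonyl carbon with 2-methyl-1,3-thiazol-4-yl gives an at least 34-fold higher number from compound 2 to compound 4 (1.53 log units; beyond the scatter), so the loss at this position is not confined to the 4-methylcyclohexyl group: an aromatic five-membered ring with two hetero atoms also fails to give a number. The steps from compound 3 to compound 4 and from compound 1 to compound 4 cannot be read, since both ends of each are limits. Among the carbonyl substituents shown, only cyclopropyl in compound 2 gives a number in this assay, and the series now rests mainly on limits: the limit of > 10000 nM in this assay, at which 3 of the 4 values shown sit.

The compounds shown leave open whether a cyclobutyl, an isopropyl or a plain methyl on the carbonyl carbon would keep a number. They also leave open how far compounds 1, 3 and 4 lie from one another.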